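Swapping the aryl group on the shared core

A few compounds are considered here, and "the series" means these few. Any claim that something is new, unique, unknown or untested is made for them only; others in the source may bear on it.

Compound 2 `Oc1ccccc1/C=N/c1nnc(SCc2nnc(-c3ccc(Br)cc3)o2)s1` shows the highest of the two numbers in a functional assay on SMMC-7721 cells (Homo sapiens) for inhibition, read by CCK-8 assay (on this read-out higher numbers stand for weaker inhibition and lower numbers for stronger inhibition), giving 18000 nM, while compound 1 `Oc1ccccc1/C=N/c1nnc(SCc2nnc(-c3ccccc3)o2)s1` gives 7100 nM. Among the measured compounds shown here, the single measured step, a 2.5-fold higher number from compound 1 to compound 2 (0.40 log units; beyond the scatter), is the only guide to this position. Compound 3 `Cc1ccccc1-c1nnc(CSc2nnc(/N=C/c3ccccc3O)s2)o1` differs from compound 2 by 2-methylphenyl in place of 4-bromophenyl on an aromatic carbon. Since that change is not the reverse of the measured one, a modest shift in this assay toward compound 1, or none beyond the scatter, is expected. Compound 3 is therefore estimated at 10000 nM, within 4000 nM to 25000 nM, an expected step of a 1.8-fold lower number from compound 2 to compound 3 (0.26 log units; within the scatter).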

Compound 3, half-maximal inhibitory concentration: 15500 nM
Compound 3: the middle estimate sits 1.6-fold (0.19 log units) below what was measured; the measured number falls inside the stated range.
By their numbers in this assay, from the lowest: compound 1; then compounds 3 and 2 (each within the scatter of the next).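

In this assay, 2-methylphenyl in place of 4-bromophenyl gives a 1.2-fold lower number from compound 2 to compound 3 (0.06 log units; within the scatter), so these two groups cannot be told apart at this position. Methyl in place of hydrogen gives a 2.2-fold higher number from compound 1 to compound 3 (0.34 log units; beyond the scatter), so a second substituent, different in kind and place from bromo, also raises the number from compound 1. Nothing shown accounts for these steps.

On these data alone, whether any substituent on this aryl ring can lower the number below that of compound 1 remains open, for example an amine or a carboxylic acid.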